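A few compounds are considered here, and "the series" means these few. Any claim that something is new, unique, unknown or untested is made for them only; others in the source may bear on it.

Measured compounds:
compound 1 `COc1cc(-n2cnc3ccc(-c4ccc(O)cc4)cc32)cc(OC)c1OC`, > 10000 nM
compound 2 `COc1cc(-n2cnc3ccc(-c4ccc(C)cc4)cc32)cc(OC)c1OC`, 200 nM

In a functional assay on SGC-7901 cells (Homo sapiens) for antiproliferative activity, read by MTT assay, with a stated time of 72 h (a lower number here means a stronger inhibitor, a higher number a weaker inhibitor), compound 1 gives > 10000 nM, which is a limit of the assay and not a number. In this assay compound 2 gives 200 nM, the only number shown in the series. Going by the values given here, the single measured step, an at least 50-fold lower number from compound 1 to compound 2 (1.69 log units; beyond the scatter), runs from the limit of > 10000 nM in this assay, at which 1 of the 2 values shown sits, and is large. Compound 3 `COc1cc(-n2cnc3ccc(-c4cccc(Cl)c4)cc32)cc(OC)c1OC` carries 3-chlorophenyl in place of 4-methylphenyl on an aromatic carbon. Among the compounds with values here, the change from methyl to hydroxy is the only measured precedent and differs in kind from this swap, so it bears on compound 3 only loosely. The expected step of a 1.5-fold higher number from compound 2 to compound 3 (0.18 log units; within the scatter) is small. Compound 3 is estimated at 300 nM, range 100 nM to 1500 nM.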

Compound 3, half-maximal inhibitory concentration: 1490 nM
Compound 3: middle estimate off by 5.0-fold (0.70 log units), on the low side, within the range that was stated.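

In this assay, 3-chlorophenyl in place of 4-methylphenyl gives a 7.5-fold higher number from compound 2 to compound 3 (0.87 log units; beyond the scatter), so the number moves even though neither group carries a hydrogen-bond donor or acceptor. Against 4-hydroxyphenyl, 3-chlorophenyl still gives an at least 6.7-fold lower number from compound 1 to compound 3 (0.82 log units; beyond the scatter), which places compound 3 between its two neighbours. Compound 1 remains a limit of the assay and not a number, so that step is only a bound: the limit of > 10000 nM in this assay, at which 1 of the 3 values shown sits.

The swap changes both the substituent and its ring position, and the compounds shown do not separate the two. On these data alone, how 3-methylphenyl, 4-chlorophenyl or an amine on this ring would read stays open.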